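A few compounds are considered here, and "the series" means these few. Any claim that something is new, unique, unknown or untested is made for them only; others in the source may bear on it.

Measured so far in a functional assay on SW480 cells (Homo sapiens) for cytotoxicity, read by MTT assay, with a stated time of 24 h; a lower number here means a stronger inhibitor, a higher number a weaker inhibitor:

Compound 1 `C=CC1=C(C(=O)O)C(c2ccc(F)cc2)OC1` — > 100000 nM
Compound 2 `C=CC1=C(C(=O)O)C(c2ccc(OC)cc2)OC1` — > 100000 nM

Compound 2 stands at a limit in this assay: the value given for compound 2, > 100000 nM, is a limit of the assay and not a number. The only step measured among these compounds, a step that the two limits leave unreadable from compound 1 to compound 2, runs between two such limits and is therefore of unreadable size. The evidence behind this is the limit of > 100000 nM in this assay, at which 2 of the 2 values shown sit, so nothing measured here tells how far either compound lies beyond the limit.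

Compound 3 `C=CC1=C(C(=O)Nc2ccccc2)C(c2ccc(OC)cc2)OC1` differs from compound 2 in one place: anilino in place of hydroxy on a carbonyl carbon. Going by the values given here, no measured step bears on this change, since the one step measured concerns a different place and is itself unreadable. Compound 3 is therefore expected, by this account, to sit near the same limit, with the step of an at least 1.2-fold lower number from compound 2 to compound 3 (0.09 log units; that floor lies within the scatter) expected to be small or not readable at all in this assay. For compound 3 the estimate in this assay is 80000 nM, with a range from 20000 nM to 300000 nM.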

Compound 3, half-maximal inhibitory concentration: > 100000 nM
Compound 3: no number, only a limit; the forecaster's own chance of this, stated with the estimate: 60%; at least 1.2-fold (0.09 log units) between middle value and limit.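

In this assay compound 3 gives > 100000 nM, which is a limit and not a number. No step can be read between compound 2 and compound 3, as both stand at a limit: the limit of > 100000 nM in this assay, at which 3 of the 3 values shown sit. The compounds shown leave open whether any change to the shared core would give a measurable value in this assay.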